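A Longer Side Chain on Compound 1: What to Expect

The source may report more compounds than this note shows. Statements on the series, on what has been measured and on what is new or still open speak of the compounds shown alone.

Of the compounds shown here, two have been tested so far in an ADME assay on WI-38 cells (Homo sapiens) for cytotoxicity, read by MTT assay, with a stated time of 72 h; a higher number here means a weaker inhibitor, a lower number a stronger inhibitor. Compound 1 `Cn1cnnc1-c1cc(Oc2ccc(NC(=O)Nc3cccc(C(F)(F)F)c3)cc2F)ccn1` gives 12600 nM, the lowest of the two numbers. Its nearest neighbour is compound 2 `CCN(CC)CCn1cnnc1-c1cc(Oc2ccc(NC(=O)Nc3ccc(F)c(Cl)c3)cc2F)ccn1`, which in this assay gives 28700 nM, a gap beyond the usual scatter; compound 2 differs from compound 1 in more than one place, so only the two values themselves can be compared. Compound 3 `CN(C)CCCn1cnnc1-c1cc(Oc2ccc(NC(=O)Nc3cccc(C(F)(F)F)c3)cc2F)ccn1` has not yet been measured. It differs from compound 1 in one place: 2-(dimethylamino)ethyl in place of hydrogen on a saturated chain carbon bound to an aromatic nitrogen. For the measured compounds named here, no measured pair isolates this change. Compound 2 carries a chain on the same part of the structure, and its number sits higher. A modest move towards a weaker inhibitor is therefore expected for compound 3, a 1.4-fold higher number from compound 1 to compound 3 (0.15 log units; within the scatter), though a step within the scatter would not surprise. Compound 3 is expected to give about 18000 nM, with a likely range from 7000 nM to 45000 nM.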

Compound 3, half-maximal inhibitory concentration: 11600 nM
Beside the measured number, compound 3's estimate is 1.6-fold (0.19 log units) above it; the measured number falls inside the stated range.
By their numbers in this assay, from the lowest: compounds 3 and 1 (each within the scatter of the next); then compound 2.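

Putting 2-(dimethylamino)ethyl in place of hydrogen on a saturated chain carbon bound to an aromatic nitrogen gives, in this assay the assay's first single-change comparison at this position: a 1.1-fold lower number from compound 1 to compound 3 (0.04 log units; within the scatter) which places the two numbers within the scatter of each other. Going from methyl to 3-(dimethylamino)propyl at this position therefore leaves no readable difference in this measurement, even though the entering group adds a nitrogen and a run of carbons. Nothing measured here accounts for this result.

Still open, as far as these compounds go, is whether a longer chain, or one ending in a morpholine or a carboxylic acid, would give a similar number. From the compounds shown here alone, it is also open whether this same chain would behave alike if a chlorine atom replaced the trifluoromethyl group of compound 1.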